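The compounds below may be only part of what the source reports. "The series", "measured", "known", "first", "only" and "open" are said of these compounds alone.

Measured so far in an in vitro ADME assay on microsomes from liver (Homo sapiens) for pharmacokinetics; on this read-out lower numbers stand for slow clearance and higher numbers for fast clearance:
- Compound 1 `Cc1ccc(S(=O)(=O)N2C=CNC(=O)[C@H]2CC(=O)N[C@@H]2CCCc3ccccc32)cc1`: 514 mL.min-1.g-1
- Compound 2 `Cc1ccc(S(=O)(=O)N2C=CNC(=O)[C@H]2CC(=O)N[C@H]2CCN(C)CC2(C)C)cc1`: < 14 mL.min-1.g-1 (a limit, not a number)

As far as these compounds go, compound 2 stands at the limit of < 14 mL.min-1.g-1 in this assay, at which 1 of the 2 values shown sits, so only a limit is known for it and its true position remains open.

Compound 3 `Cc1ccc(S(=O)(=O)N2C=CNC(=O)[C@H]2CC(=O)N[C@H]2CCN(C3CCC3)CC2(C)C)cc1` carries cyclobutyl in place of methyl on an amine nitrogen in a ring. The rest of compound 2 stays unchanged.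

Going by the values given here, only one measured step bears on this change, and only indirectly. The large step of an at least 36-fold lower number from compound 1 to compound 2 (1.56 log units; beyond the scatter) lies beyond the scatter, but it exchanged the whole group on the amide-type nitrogen. The present change keeps the six-membered non-aromatic ring with 1 nitrogen that entered on that step and alters only the group on its amine nitrogen. Among the compounds with values here, no measured step isolates that position, so a modest move to a higher number in this assay is expected, far smaller than that large step and possibly within the scatter.

The expected step is an at least 1.7-fold higher number from compound 2 to compound 3 (0.25 log units; that floor lies within the scatter). For compound 3 the estimate is 25 mL.min-1.g-1, with an expected range of 10 mL.min-1.g-1 to 75 mL.min-1.g-1.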

Compound 3, intrinsic clearance in microsomes: 24 mL.min-1.g-1
The estimate for compound 3 lay 1.0-fold (0.02 log units) above the measured number; the measured number falls inside the stated range.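

Going by these compounds alone, this is the first step that isolates the amine nitrogen of the six-membered non-aromatic ring: in this assay, cyclobutyl in place of methyl gives an at least 1.7-fold higher number from compound 2 to compound 3 (0.23 log units; that floor lies within the scatter). Within the data shown here, for compound 2 the value < 14 mL.min-1.g-1 is a limit and not a number, so this step has only a floor, and its true size stays unread: the limit of < 14 mL.min-1.g-1 in this assay, at which 1 of the 3 values shown sits. Compound 3 gives 24 mL.min-1.g-1, which is the first actual number for a compound carrying this ring and a fixed reference for further changes on this nitrogen.

The compounds shown leave open how a hydrogen, an isopropyl group or a benzyl group on this amine nitrogen would read in this assay, and whether the number follows the size of the group at all. As far as these compounds go, the ring atom that bears two methyl groups is also the same in compound 2 and compound 3, so its share in these numbers remains unknown.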